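Changing the Side Group of Compound 1

A few compounds are considered here, and "the series" means these few. Any claim that something is new, unique, unknown or untested is made for them only; others in the source may bear on it.

In a functional assay on MDA-MB-231 cells (Homo sapiens) for cytotoxicity, read by MTT assay, with a stated time of 72 h (on this read-out lower numbers stand for stronger inhibition and higher numbers for weaker inhibition), compound 1 `CC1(C)OCC(Cn2cc(Cn3c4c(c5ccccc53)C(=O)c3c[n+]([O-])c5ccccc5c3C4=O)nn2)O1` gives 230 nM, the middle of three numbers: compound 2 `CN1CCN(CCCCn2c3c(c4ccccc42)C(=O)c2c[n+]([O-])c4ccccc4c2C3=O)CC1` gives 110 nM and compound 3 `O=C1c2c[n+]([O-])c3ccccc3c2C(=O)c2c1c1ccccc1n2CCCCN1CCNCC1` gives 3310 nM. Compound 4 `O=C1c2c[n+]([O-])c3ccccc3c2C(=O)c2c1c1ccccc1n2Cc1cn([C@@H]2O[C@H](CO)[C@@H](O)[C@H](O)[C@H]2O)nn1` is still unmeasured. On an aromatic nitrogen of a five-membered aromatic ring with 3 nitrogen, it carries 3,4,5-trihydroxy-6-(hydroxymethyl)oxan-2-yl in place of (2,2-dimethyl-1,3-dioxolan-4-yl)methyl (3,4,5-trihydroxy-6-(hydroxymethyl)oxan-2-yl in place of (2,2-dimethyl-1,3-dioxolan-4-yl)methyl on an aromatic nitrogen). Among the compounds with values here, the only measured step, a 30-fold higher number from compound 2 to compound 3 (1.48 log units; beyond the scatter), puts hydrogen in place of methyl on an amine nitrogen in a ring. It is a different change, so it offers only a loose guide: one swap can move this number far, here upward. The expected change is modest, a 2.6-fold higher number from compound 1 to compound 4 (0.42 log units; beyond the scatter). For compound 4 the estimate is 600 nM, within an expected range from 150 nM to 2500 nM.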

Compound 4, half-maximal inhibitory concentration: 650 nM
For compound 4 the middle estimate is 1.1-fold (0.03 log units) below the measured one, within the range that was stated.
By their numbers in this assay, from the lowest: compound 2; then compound 1; then compound 4; then compound 3.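

Replacing (2,2-dimethyl-1,3-dioxolan-4-yl)methyl with 3,4,5-trihydroxy-6-(hydroxymethyl)oxan-2-yl on this aromatic nitrogen gives a 2.8-fold higher number from compound 1 to compound 4 (0.45 log units; beyond the scatter) in this assay, a modest loss. So this position accepts a group with 4 hydrogen-bond donors in place of one with 0, and the cytotoxicity weakens but is not lost. The data shown offer no explanation for this shift. Still open, on these data alone, is how a carboxylic acid or an amine on this nitrogen would compare. It is also unclear whether a longer chain between the sugar ring and the aromatic nitrogen would move the number.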